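This account rests on a few compounds, and the source may have more. Where it says the series, first, only, none or still open, it means among the compounds named here.

Three compounds were measured in an assay on CHO cells for displacement of a labelled ligand from adenosine receptor A3 (Homo sapiens), tested at 10 uM; a lower number here means less inhibition, a higher number more inhibition at the concentration tested (going by the name of the read-out). Compound 2 `Nc1ncnc2c1ncn2[C@@H]1OC[C@@](O)(CO)[C@H]1O` gives 10% in this assay, and its diastereomer compound 3 `Nc1ncnc2c1ncn2[C@@H]1OC[C@](O)(CO)[C@H]1O` gives 35%. Within the data shown here, the two share every atom and bond, the difference between them being (the two compounds have the same atoms and bonds and differ only in configuration as drawn: 1 of 3 stereo elements differ; a stereocentre at a saturated ring carbon is drawn S in compound 2 and R in compound 3), and the step of a number 25 percentage points higher from compound 2 to compound 3 (beyond the scatter) is attributed to that alone because the fact that compounds 2 and 3 differ only in the configuration as drawn is the only distinction between the pair. Compound 1 `OC[C@]1(O)CO[C@@H](n2cnc3c(NCc4cccc(I)c4)ncnc32)[C@@H]1O` carries the change 3-iodobenzyl in place of hydrogen on a nitrogen on an aromatic ring on the shared core; in this assay compound 1 gives 45%, the step of a number 35 percentage points higher from compound 2 to compound 1 (beyond the scatter) being the largest in the set.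

Compound 4 `OC[C@@]1(O)CO[C@@H](n2cnc3c(NCc4cccc(I)c4)ncnc32)[C@@H]1O` has not yet been measured in this assay. It stands to compound 3 exactly as compound 1 stands to compound 2: the change is 3-iodobenzyl in place of hydrogen on a nitrogen on an aromatic ring, at a place described in the same words for both pairs, so it is the same change made on the other core. Since the same change gave the step of a number 35 percentage points higher from compound 2 to compound 1 (beyond the scatter), a step of similar size is expected here, a number 30 percentage points higher from compound 3 to compound 4 (beyond the scatter), starting from the higher value of compound 3. Compound 4 is therefore estimated at 65% in this assay, with a range from 45% to 85%.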

Compound 4, a percentage reported as inhibition, at one concentration (the size of the read-out at that concentration, not a potency): 48%
The estimate for compound 4 lay 17 percentage points above the measured number, and the stated range covers the measured number.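

In this assay the change to 3-iodobenzyl on the nitrogen again goes with a higher number, a number 13 percentage points higher from compound 3 to compound 4 (beyond the scatter), so the direction carries over to the second core, but the size of the step does not: the same change on two cores in this assay, a number 35 percentage points higher (beyond the scatter) from compound 2 to compound 1 and a number 13 percentage points higher (beyond the scatter) from compound 3 to compound 4, 22 percentage points apart, beyond the scatter of two such steps. The drawn configuration at the saturated ring carbon separates the two compounds without the group beyond the scatter, yet with 3-iodobenzyl in place the two configurations cannot be told apart, a number 3 percentage points higher from compound 1 to compound 4 (within the scatter), and this step can be read as one of configuration alone: the fact that compounds 1 and 4 differ only in the configuration as drawn. This shows that the step for this change depends on the core in these two pairs, but it does not show why, and two pairs cannot say how the change would behave on any further core.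

The compounds shown leave open whether the iodine matters, since an unsubstituted benzyl or a 3-chlorobenzyl on that nitrogen does not appear among them. They also leave open what a longer chain there would do on either core.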